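Replacing a hydroxyphenyl with furanyl on the pyrazoline core

The source may report more compounds than this note shows. Statements on the series, on what has been measured and on what is new or still open speak of the compounds shown alone.

Compound 1 `O=C(c1ccncc1)N1N=C(c2cc3ccccc3o2)CC1c1ccccc1O` carries a 2-hydroxyphenyl group on the saturated ring carbon of its core. In an ADME assay on Vero cells (Chlorocebus sabaeus) for cytotoxicity, read by MTT assay, with a stated time of 72 h (a higher number here means a weaker inhibitor, a lower number a stronger inhibitor), compound 1 gives only a limit of > 195000 nM, so no number is known for it. Compound 2 `O=C(c1ccncc1)N1N=C(c2cc3ccccc3o2)CC1c1ccccc1` also gives only a limit in this assay, namely > 209000 nM. The step that the two limits leave unreadable from compound 1 to compound 2 therefore cannot be read, since both values sit at their limits the limit of > 195000 nM in this assay, at which 1 of the 2 values shown sits (the limit of > 209000 nM in this assay, at which 1 of the 2 values shown sits). Compound 3 `O=C(c1ccncc1)N1N=C(c2cc3ccccc3o2)CC1c1ccco1` differs from compound 1 as follows: furan-2-yl in place of 2-hydroxyphenyl on a saturated ring carbon. Among the compounds with values here, no measured step speaks directly to this change, and the one step available is unreadable, so no size or direction of change beyond the scatter can be anticipated. Compound 3 is thus expected to remain at or near the limit of this assay, with an estimated step that the limit leaves unreadable from compound 1 to compound 3. The estimated value for compound 3 is 250000 nM, within a range of 100000 nM to 600000 nM.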

Compound 3, half-maximal inhibitory concentration: > 208000 nM
Compound 3: a limit, no number (the forecaster's own chance of this, stated with the estimate: 80%); the middle value lies beyond the limit too.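

Compound 3, like compound 1 and compound 2, gives only a limit and no number in this assay, so none of the steps among these three compounds can be read. The compounds shown leave open how 2-hydroxyphenyl, phenyl and furan-2-yl on a saturated ring carbon compare in this assay.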